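Side-chain variation at the saturated ring carbon

The compounds below may be only part of what the source reports. "The series", "measured", "known", "first", "only" and "open" are said of these compounds alone.

For the measured compounds named here, compound 1 `Cn1ncc(Cl)c1-c1cc(C(=O)N[C@@H]2CN[C@H](CC(O)CO)C[C@H]2c2ccc(Cl)c(Cl)c2)oc1Cl` gives 1110 nM in a functional assay on HCT-116 cells (Homo sapiens) for antiproliferative activity, read by sulforhodamine B assay, with a stated time of 72 h (on this read-out lower numbers stand for stronger inhibition and higher numbers for weaker inhibition), the highest of the three numbers so far. Compound 2 `Cn1ncc(Cl)c1-c1cc(C(=O)N[C@@H]2CN[C@H](CC(N)=O)C[C@H]2c2ccc(Cl)c(Cl)c2)oc1Cl` gives 650 nM and compound 3 `Cn1ncc(Cl)c1-c1cc(C(=O)N[C@@H]2CN[C@H](CCO)C[C@H]2c2ccc(Cl)c(Cl)c2)oc1Cl` gives 340 nM; the step of a 3.3-fold lower number from compound 1 to compound 3 (0.51 log units; beyond the scatter) is modest, while a 1.7-fold lower number from compound 1 to compound 2 (0.23 log units; within the scatter) and a 1.9-fold lower number from compound 2 to compound 3 (0.28 log units; within the scatter) stay within the scatter. Compound 4 `Cn1ncc(Cl)c1-c1cc(C(=O)N[C@@H]2CN[C@H](CC(=O)NC3CCC3)C[C@H]2c2ccc(Cl)c(Cl)c2)oc1Cl` carries cyclobutylcarbamoyl in place of 1,2-dihydroxyethyl on a saturated chain carbon bound to a saturated ring carbon. The nearest measured step is a 1.7-fold lower number from compound 1 to compound 2 (0.23 log units; within the scatter), in which a plain carbamoyl entered at the same place; no substituted carbamoyl has been measured, so the cyclobutyl part is uncharted. The step of a 2.0-fold lower number from compound 1 to compound 4 (0.30 log units; within the scatter) is expected to be small and towards a lower number because a 1.7-fold lower number from compound 1 to compound 2 (0.23 log units; within the scatter) is the closest guide. Compound 4 is estimated at 550 nM, with a range of 200 nM to 1500 nM.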

Compound 4, half-maximal inhibitory concentration: 430 nM
Compound 4: middle estimate off by 1.3-fold (0.11 log units), on the high side, within the range that was stated.
By their numbers in this assay, from the lowest: compounds 3, 4, 2 and 1 (each within the scatter of the next, the first and the last beyond it).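

A cyclobutyl on the amide-type nitrogen leaves this position within the scatter of the plain carbamoyl (a 1.5-fold lower number from compound 2 to compound 4 (0.18 log units; within the scatter)), so a substituted carbamoyl is accommodated here. Unlike the plain carbamoyl, cyclobutylcarbamoyl in place of 1,2-dihydroxyethyl gives a step beyond the scatter (a 2.6-fold lower number from compound 1 to compound 4 (0.41 log units; beyond the scatter)), while the comparison with the compound 3 side chain stays within it (a 1.3-fold higher number from compound 3 to compound 4 (0.10 log units; within the scatter)). Nothing available explains these steps.

Still open, on these data alone, is how a phenyl or cyclohexyl on the amide-type nitrogen would read at this position, and how a carboxylic acid or an amine on the same chain carbon would compare.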